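Replacing the thiazolylmethyl group on the ring nitrogen

A few compounds are considered here, and "the series" means these few. Any claim that something is new, unique, unknown or untested is made for them only; others in the source may bear on it.

Compound 1 `OC[C@@H](O[C@H]1CCCN(Cc2cccc3nonc23)[C@H]1c1ccccc1)c1cc(Cl)cc(Cl)c1` gives 8000 nM in an assay on isolated protein for activation of cGMP-dependent protein kinase 1 (Homo sapiens), read by ADP-Glo, with stated times of 120 min and 40 min; a lower number here means that less compound is needed, a higher number that more compound is needed for the effect. Compound 3 `O=C(O)c1ccc2c(CN3CCC[C@H](O[C@H](CO)c4cc(Cl)cc(Cl)c4)[C@@H]3c3ccccc3)c[nH]c2c1` gives 22000 nM in this assay, so that a 2.8-fold higher number from compound 1 to compound 3 (0.44 log units; beyond the scatter). Compound 2 `Clc1cc(Cl)cc(CO[C@H]2CCCN(Cc3nccs3)[C@H]2c2ccccc2)c1` reaches only a limit of this assay, > 200000 nM, with no number attached. Compound 4 `Clc1cc(Cl)cc(CO[C@H]2CCCN(Cc3ccc(-c4nn[nH]n4)cc3)[C@H]2c2ccccc2)c1` differs from compound 2 by 4-(2H-tetrazol-5-yl)phenyl in place of 1,3-thiazol-2-yl on a saturated chain carbon bound to an amine nitrogen in a ring. For the measured compounds named here, the only measured step at this place is the one from compound 1 to compound 3, which was modest; the change to compound 4 is larger in size, yet no measured pair shows a larger swing at this place. Compound 4 is therefore expected to stay weak, with an estimated 120000 nM (range 30000 nM to 400000 nM), meaning an expected step of an at least 1.6-fold lower number from compound 2 to compound 4 (0.22 log units; that floor lies within the scatter), with a real chance that only a limit is reported again.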

Compound 4, half-maximal effective concentration: 74000 nM
Compound 4: the middle estimate sits 1.6-fold (0.21 log units) above what was measured; measured number inside the range.
By their numbers in this assay, from the lowest: compound 1; then compound 3; then compound 4. At a limit, above all of these: compound 2.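

With 4-(2H-tetrazol-5-yl)phenyl in place of 1,3-thiazol-2-yl on a saturated chain carbon bound to an amine nitrogen in a ring, the series shows an at least 2.7-fold lower number from compound 2 to compound 4 (0.43 log units; beyond the scatter), so this place can turn a compound without a number into one with a measurable number. From the compounds shown here alone, compound 2 stands at a limit, so the step is a floor and its full size stays unknown: the limit of > 200000 nM in this assay, at which 1 of the 4 values shown sits.

The compounds shown leave open whether the step comes from the phenyl ring or from the tetrazole. Going by these compounds, how a plain phenyl, or a phenyl bearing a carboxylic acid, would read at this place also remains open.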